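Replacing 2-Chlorophenyl With 4-Hydroxyphenyl in Compound 2

This account rests on a few compounds, and the source may have more. Where it says the series, first, only, none or still open, it means among the compounds named here.

Compound 2 `CCCSc1nc(N/N=C(\C)c2ccccc2O)c2nnn(Cc3ccccc3Cl)c2n1` gives only a limit in a functional assay on MCF7 cells (Homo sapiens) for antiproliferative activity, read by MTT assay, with a stated time of 72 h; on this read-out lower numbers stand for stronger inhibition and higher numbers for weaker inhibition: compound 2 gives > 64000 nM, a limit rather than a number. Compound 2 thus sits at the limit of > 64000 nM in this assay, at which 2 of the 3 values shown sit. Compound 1 `CCCSc1nc(N/N=C/c2ccccc2F)c2nnn(Cc3ccccc3)c2n1` likewise gives a limit in this assay, > 64000 nM. Compound 3 `CCCSc1nc(N/N=C(\C)c2ccc(O)cc2)c2nnn(Cc3ccccc3)c2n1` gives 21600 nM in this assay. Going by the values given here, the only measured step, an at least 2.9-fold lower number from compound 1 to compound 3 (0.47 log units; beyond the scatter), alters a different group than the one changed in compound 4 `CCCSc1nc(N/N=C(\C)c2ccccc2O)c2nnn(Cc3ccc(O)cc3)c2n1`, whose difference from compound 2 is 4-hydroxyphenyl in place of 2-chlorophenyl on a saturated chain carbon bound to an aromatic nitrogen. Since a group of the same name accompanies the measurable number of compound 3, 21600 nM, a modest move toward lower numbers is expected, with a step of an at least 1.4-fold lower number from compound 2 to compound 4 (0.15 log units; that floor lies within the scatter) estimated. Compound 4 is therefore expected near 45000 nM, between 15000 nM and 120000 nM.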

Compound 4, half-maximal inhibitory concentration: 9520 nM
Compound 4: middle estimate off by 4.7-fold (0.67 log units), on the high side; the measured number lies below the stated range.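

In this assay, the change on this saturated chain carbon bound to an aromatic nitrogen gives an at least 6.7-fold lower number from compound 2 to compound 4 (0.82 log units; beyond the scatter). This shows that 4-hydroxyphenyl in place of 2-chlorophenyl at this place can alone bring a compound from a limit to a measured number, which the earlier step, made elsewhere, could not show. The size of the step is only a floor, as compound 2 gives a limit rather than a number: the limit of > 64000 nM in this assay, at which 2 of the 4 values shown sit.

The compounds shown leave open whether the shift comes from losing 2-chlorophenyl or from gaining 4-hydroxyphenyl. They also leave open how a 4-aminophenyl or 4-methoxyphenyl group would read at this place.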